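This account rests on a few compounds, and the source may have more. Where it says the series, first, only, none or still open, it means among the compounds named here.

Of the compounds shown here, three have so far been tested in a functional assay on KB cells (Homo sapiens) for inhibition, read by MTT assay, with a stated time of 24 h, tested at 10 ug/mL; a higher number here means more inhibition of growth at the concentration tested, a lower number less inhibition of growth. Compound 1 `O=C(O)CCCCC(CCSC(=O)c1ccccc1)SC(=O)c1ccccc1` gives 2.68%, and compound 3 `O=C(CCCCC(CCSC(=O)c1ccccc1)SC(=O)c1ccccc1)Nc1ccccc1` gives 2.67%, so these two stand level within the scatter. Compound 2 `O=C(CCCCC(S)CCS)Nc1ccc([N+](=O)[O-])cc1` gives 13.7%, which lies beyond the scatter above both. Compound 3 therefore sits with compound 1 at the low end of this small set.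

The next compound, compound 4 `O=C(CCCCC(CCSC(=O)c1ccccc1)SC(=O)c1ccccc1)Nc1ccccc1Cl`, keeps all of compound 3 except for one atom on the anilide ring: chloro in place of hydrogen on an aromatic carbon. This is chloro in place of hydrogen on an aromatic carbon, ortho to a large group, turning phenylcarbamoyl into (2-chlorophenyl)carbamoyl.

Among the compounds with values here, only one measured step bears on this change. It is a number 0 percentage points lower from compound 1 to compound 3 (within the scatter), where anilino replaces hydroxy on a carbonyl carbon, at the same end of the molecule. Within the data shown here, no measured pair tests a chloro directly, and compound 2 differs from compound 3 in more than one place, so it offers no clean comparison. With so little evidence, no shift beyond the scatter is expected in this assay. The expected a number 1.3 percentage points higher from compound 3 to compound 4 (within the scatter) is small and could fall in either direction. For compound 4 the estimated value is 4%, with an expected range from 0% to 14%.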

Compound 4, percent growth inhibition at one concentration: 2.53%
Compound 4: the middle estimate sits 1.5 percentage points above what was measured; low and high end bracket the measured number.
By their numbers in this assay, from the lowest: compounds 4, 3 and 1 (each within the scatter of the next); then compound 2.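

Adding a chloro on an aromatic carbon, ortho to a large group, turns phenylcarbamoyl into (2-chlorophenyl)carbamoyl, and in this assay this gives a number 0.1 percentage points lower from compound 3 to compound 4 (within the scatter), so this substitution leaves no measurable mark on growth inhibition. The comparison with the parent acid points the same way, with a number 0.2 percentage points lower from compound 1 to compound 4 (within the scatter), which shows that even (2-chlorophenyl)amino in place of hydroxy on the carbonyl carbon does not lift the reading beyond the scatter. No measurement available here offers a reason why the change at this position makes no visible difference.

From the compounds shown here alone, it remains open whether a methoxy group or an amine in place of the chloro, or a longer chain in place of the aromatic ring on the amide nitrogen, would shift the number in this assay beyond the scatter. These readings also come from a single concentration, so how compound 3 and compound 4 would compare at other concentrations is not settled by the compounds shown.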